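Chlorophenyl series on the shared core: compound 3 to compound 4

The compounds below may be only part of what the source reports. "The series", "measured", "known", "first", "only" and "open" are said of these compounds alone.

The series is three compounds on one core, tested in a functional assay on A549 cells (Homo sapiens) for inhibition, read by MTT assay, with a stated time of 24 h; a lower number here means a stronger inhibitor, a higher number a weaker inhibitor. Compound 1 `CC1(C)[C@H]2CC[C@]1(C)N(Cc1cn(-c3cccc(Cl)c3)nn1)C(=O)C2` gives 60 nM, and compound 2 `CC1(C)[C@H]2CC[C@]1(C)N(Cc1cn(-c3ccc(Cl)cc3)nn1)C(=O)C2` gives 70 nM; the step of a 1.2-fold higher number from compound 1 to compound 2 (0.07 log units; within the scatter) shows that moving the chloro from 3-chlorophenyl to 4-chlorophenyl changes nothing beyond the scatter. Compound 3 `CC1(C)[C@H]2CC[C@]1(C)N(Cc1cn(-c3cccc(O)c3)nn1)C(=O)C2` gives 180 nM, the highest number of the three and therefore the weakest inhibitor here, with a 3.0-fold higher number from compound 1 to compound 3 (0.48 log units; beyond the scatter) and a 2.6-fold higher number from compound 2 to compound 3 (0.41 log units; beyond the scatter).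

Compound 4 `CC1(C)[C@H]2CC[C@]1(C)N(Cc1cn(-c3ccccc3Cl)nn1)C(=O)C2` is not yet measured. The change from compound 3 is 2-chlorophenyl in place of 3-hydroxyphenyl on an aromatic nitrogen. Among the compounds with values here, two measured steps bear on it: the hydroxy-for-chloro swap in a 3.0-fold higher number from compound 1 to compound 3 (0.48 log units; beyond the scatter) cost a modest amount, so putting a chloro back in place of the hydroxy should recover that; and a 1.2-fold higher number from compound 1 to compound 2 (0.07 log units; within the scatter) suggests that the ring position of the chloro makes little difference, though the 2-chlorophenyl position itself is untested. A lower number in this assay is therefore expected for compound 4, of about a 2.6-fold lower number from compound 3 to compound 4 (0.41 log units; beyond the scatter). The estimate for compound 4 is 70 nM, with a range of 35 nM to 150 nM.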

Compound 4, half-maximal inhibitory concentration: 70 nM
Compound 4: the middle estimate sits on the measured number at the digits printed; the measured number falls inside the stated range.
By their numbers in this assay, from the lowest: compounds 1, 2 and 4 (each within the scatter of the next); then compound 3.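

Among the chlorophenyl compounds, the 2-chlorophenyl group adds a third ring position for the chloro in this assay, and the position still does not separate them: no change at the digits printed from compound 2 to compound 4 (within the scatter) and a 1.2-fold higher number from compound 1 to compound 4 (0.07 log units; within the scatter) both lie within the scatter. Compound 4 also extends the gap to the hydroxy compound, with a 2.6-fold lower number from compound 3 to compound 4 (0.41 log units; beyond the scatter) showing that it persists when the chloro stands at a different ring position from the hydroxy, so compound 3 is now set apart from all three chlorophenyl compounds. No measurement in hand explains this gap.

Going by these compounds, whether an amine or a carboxylic acid on the same phenyl ring would track compound 3 or the chlorophenyl compounds remains open. Also open is whether a hydroxy group tolerates a shift around the ring as the chloro does, since 3-hydroxyphenyl is the only hydroxy example shown.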